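This account rests on a few compounds, and the source may have more. Where it says the series, first, only, none or still open, it means among the compounds named here.

The measured compounds:

Compound 1, `Cc1cccc(/C=N/Nc2ncc3c(n2)n(C2CCCC2)c(=O)c(=O)n3C)c1`. In a functional assay on HCT-116 cells (Homo sapiens) for antiproliferative activity, read by MTT assay (on this read-out higher numbers stand for weaker inhibition and lower numbers for stronger inhibition), compound 1 gives only a limit of the assay, > 100000 nM.
Compound 2, `Cn1c(=O)c(=O)n(C2CCCC2)c2nc(N/N=C/c3ccc(F)c(Cl)c3)ncc21`. In this assay compound 2 gives 9020 nM.
Compound 3, `Cn1c(=O)c(=O)n(C2CCCC2)c2nc(N/N=C/c3ccc(F)cc3Cl)ncc21`. In this assay compound 3 gives 13800 nM.

Compound 1 thus stands at the weak end of the three: its number is not a measurement but the ceiling of the assay, (the limit of > 100000 nM in this assay, at which 1 of the 3 values shown sits). Both measured steps leave it. The step of an at least 11-fold lower number from compound 1 to compound 2 (1.04 log units; beyond the scatter) is the larger, and the step of an at least 7.2-fold lower number from compound 1 to compound 3 (0.86 log units; beyond the scatter) is somewhat smaller, while the pair of compound 2 and compound 3 differ by a 1.5-fold higher number from compound 2 to compound 3 (0.18 log units; within the scatter).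

Compound 4, `Cc1ccc(/C=N/Nc2ncc3c(n2)n(C2CCCC2)c(=O)c(=O)n3C)cc1C`, is not yet measured. It differs from compound 1 in one place: methyl in place of hydrogen on an aromatic carbon. For the measured compounds named here, no measured step is of this kind; the two steps that start from compound 1 exchange the whole 3-methylphenyl for a halogenated phenyl, whereas compound 4 keeps the 3-methylphenyl and adds a methyl. The shown data therefore give no direct guide to the size of the step; the expectation is that compound 4 stays near compound 1, with a shift of an at least 1.4-fold lower number from compound 1 to compound 4 (0.15 log units; that floor lies within the scatter) expected at most. Compound 4 is estimated at 70000 nM, between 15000 nM and 300000 nM, and may well return only a limit.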

Compound 4, half-maximal inhibitory concentration: 62900 nM
Compound 4: the middle estimate sits 1.1-fold (0.05 log units) above what was measured; the range from low to high includes it.
By their numbers in this assay, from the lowest: compounds 2 and 3 (each within the scatter of the next); then compound 4. At a limit, above all of these: compound 1.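

In this assay, methyl in place of hydrogen on an aromatic carbon, ortho to a methyl group and para to a large group, gives an at least 1.5-fold lower number from compound 1 to compound 4 (0.20 log units; that floor lies within the scatter), so the 3,4-dimethylphenyl gives a measured number where the 3-methylphenyl gave none, though the floor of this step does not clear the scatter. Compound 1 stands at a limit, and for that reason the true size of the step stays unknown and could be larger than its floor: the limit of > 100000 nM in this assay, at which 1 of the 4 values shown sits. The methyl-only ring still falls short of both chloro-fluorophenyl groups, with a 4.6-fold higher number from compound 3 to compound 4 (0.66 log units; beyond the scatter) and a 7.0-fold higher number from compound 2 to compound 4 (0.84 log units; beyond the scatter), both of them beyond the scatter, so among these compounds the halogenated rings keep the lower numbers.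

The compounds shown leave open whether a methoxy, a hydroxyl or an amine in the place of the added methyl would move the number further than methyl does. They also leave open whether a single chlorine or a single fluorine on the phenyl would stay below compound 4, as the two chloro-fluorophenyl compounds do.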